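Swapping the aryl group on the amide side chain

The source may hold more compounds than are shown below. What is called first, only, known or untested is meant among the compounds shown, and "the series" means these compounds.

The series shares one core and varies the aryl group of the amide side chain. In a functional assay on A2780 cells (Homo sapiens) for antiproliferative activity, read by resazurin assay, with a stated time of 72 h (on this read-out higher numbers stand for weaker inhibition and lower numbers for stronger inhibition), compound 1 (`CN(Cc1ccccc1Cl)C(=O)c1cc2c(Cc3ccccc3)n[nH]c2cc1O`) gives 1100 nM and compound 2 (`Cc1ccccc1CN(C)C(=O)c1cc2c(Cc3ccccc3)n[nH]c2cc1O`) gives 4400 nM. Compound 3 (`CN(Cc1cccc(C(F)(F)F)c1)C(=O)c1cc2c(Cc3ccccc3)n[nH]c2cc1O`) has no number to start from, and its entry reads "not determined" (no result reported). The next comparison leads to compound 4 (`CN(Cc1ccc(Br)cc1)C(=O)c1cc2c(Cc3ccccc3)n[nH]c2cc1O`), with 4-bromophenyl in place of 3-(trifluoromethyl)phenyl on a saturated chain carbon bound to an amide-type nitrogen.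

Going by the values given here, only one measured step bears on this change: a 4.0-fold higher number from compound 1 to compound 2 (0.60 log units; beyond the scatter), with methyl in place of chloro on an aromatic carbon. It shows that a single substituent change on this aryl group can move the result in this assay by a modest amount. It involves neither group in the present change, however, and a single step sets no trend. With no number for compound 3, no size or direction can be expected for the step to compound 4. The estimate therefore rests on the two measured values, leaning towards the halogen-bearing compound 1 at 1100 nM. Compound 4 is expected at 2000 nM, with an estimated range of 700 nM to 6000 nM.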

Compound 4, half-maximal inhibitory concentration: 2800 nM
Compound 4: middle estimate off by 1.4-fold (0.15 log units), on the low side; the range from low to high includes it.
By their numbers in this assay, from the lowest: compound 1; then compounds 4 and 2 (each within the scatter of the next).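

Compound 3 has no number in this assay, and the step from it to compound 4 cannot be read. Placing 4-bromophenyl in place of 2-methylphenyl gives a 1.6-fold lower number from compound 2 to compound 4 (0.20 log units; within the scatter), so on this read-out the two aryl groups cannot be told apart, even though one carries a halogen and the other a methyl group. Placing 4-bromophenyl in place of 2-chlorophenyl gives a 2.5-fold higher number from compound 1 to compound 4 (0.41 log units; beyond the scatter), so a halogen on the aryl group does not by itself keep the number near that of compound 1 at 1100 nM, which remains the lowest of the three numbers in this set. Nothing in the data shown gives a reason for these differences.

Compounds 1 and 4 differ in both the halogen and its place on the aryl ring, which leaves open which of the two accounts for the gap between them. Also open, on these data alone, is how the series responds to an amine or a carboxylic acid on the aryl group, or to a longer chain in place of the saturated chain carbon bound to the amide-type nitrogen.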